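A few compounds are considered here, and "the series" means these few. Any claim that something is new, unique, unknown or untested is made for them only; others in the source may bear on it.

Compound 1 `CCCCOC(=O)CNC(=O)[C@H](CSc1ccc([N+](=O)[O-])cc1[N+](=O)[O-])NC(=O)CC[C@H](NC(=O)c1ccccc1)C(=O)OCCCC` carries a benzoyl group on the amide-type nitrogen of the shared core. In a toxicity assay on KB cells (Homo sapiens) for cytotoxicity, read by fluorescence, with a stated time of 3 days (a higher number here means that more compound is needed for the effect, a lower number that less compound is needed), compound 1 gives > 300 uM, which is a limit of the assay rather than a number. Compound 2 `CCCCOC(=O)CNC(=O)[C@H](CSc1ccc([N+](=O)[O-])cc1[N+](=O)[O-])NC(=O)CC[C@H](NC(=O)C(C)(C)C)C(=O)OCCCC` differs from compound 1 by tert-butyl in place of phenyl on a carbonyl carbon, and in this assay compound 2 gives 83.4 uM. That change brought an at least 3.5-fold lower number from compound 1 to compound 2 (0.55 log units; beyond the scatter), and because of the limit of > 300 uM in this assay, at which 1 of the 2 values shown sits, only the lower bound of that step is known. Compound 3 `CCCCOC(=O)CNC(=O)[C@H](CSc1ccc([N+](=O)[O-])cc1[N+](=O)[O-])NC(=O)CC[C@H](NC(=O)C(C)C)C(=O)OCCCC` makes the related change (isopropyl in place of phenyl on a carbonyl carbon). Among the measured compounds shown here, the only measured step that bears on it is the one from compound 1 to compound 2, with its at least modest lowering, so a lowering in the same direction is expected for compound 3. Compound 3 is therefore estimated at 120 uM, within a range from 50 uM to 300 uM. That estimate amounts to an expected at least 2.5-fold lower number from compound 1 to compound 3 (0.39 log units; beyond the scatter).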

Compound 3, concentration for half-maximal effect: > 300 uM
Compound 3 was reported as a limit; the forecaster's own chance of this, stated with the estimate: 30%; at least 2.5-fold (0.39 log units) between middle value and limit.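

In this assay, the lowering seen with tert-butyl does not carry over to isopropyl on this carbonyl carbon: hydrogen in place of methyl on the saturated chain carbon gives an at least 3.5-fold higher number from compound 2 to compound 3 (0.55 log units; beyond the scatter). Replacing phenyl at this position therefore does not by itself lower the number, and of the three groups shown only tert-butyl gives a value that is not a limit. The step between compound 1 and compound 3 cannot be read, because neither compound has a value that is more than a limit: the limit of > 300 uM in this assay, at which 2 of the 3 values shown sit.

On these data alone, how far compound 1 and compound 3 lie from each other beyond that limit stays open. Also open, as far as these compounds go, is whether a cyclohexyl group, a longer chain such as n-butyl, or an amine on this carbonyl carbon would give a number like that of compound 2.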